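Swapping a chloropyridine amide for a methylpyridine amide

The source may hold more compounds than are shown below. What is called first, only, known or untested is meant among the compounds shown, and "the series" means these compounds.

Compound 3 `O=C(c1cccnc1Cl)N1N=C(c2ccc(Cl)cc2)CC1c1ccc(OCc2ccccc2)cc1` gives 7710 nM in a functional assay on WM 266-4 cells (Homo sapiens) for antiproliferative activity, read by MTT assay, with a stated time of 24 h (on this read-out lower numbers stand for stronger inhibition of growth and higher numbers for weaker inhibition of growth), the lowest of three numbers, all of which lie within the scatter of one another: compound 1 `O=C(c1ccc(Cl)nc1)N1N=C(c2ccc(Cl)cc2)CC1c1ccc(OCc2ccccc2)cc1` gives 13200 nM and compound 2 `Cc1ccc(C(=O)N2N=C(c3ccc(Cl)cc3)CC2c2ccc(OCc3ccccc3)cc2)c(Cl)n1` gives 11400 nM. Compound 4 `Cc1ccc(C(=O)N2N=C(c3ccc(Cl)cc3)CC2c2ccc(OCc3ccccc3)cc2)cn1` differs from compound 3 by 6-methylpyridin-3-yl in place of 2-chloropyridin-3-yl on a carbonyl carbon. The steps already seen on this aryl group were all small: a 1.7-fold lower number from compound 1 to compound 3 (0.23 log units; within the scatter), a 1.5-fold lower number from compound 2 to compound 3 (0.17 log units; within the scatter) and a 1.2-fold lower number from compound 1 to compound 2 (0.06 log units; within the scatter), none beyond the scatter. Exchanging chlorine for methyl on this pyridine is therefore expected to move this assay little, if at all, with no direction beyond the scatter. For compound 4 the expected step is a 1.4-fold higher number from compound 3 to compound 4 (0.15 log units; within the scatter). Compound 4 is estimated at 11000 nM, with a range from 5000 nM to 25000 nM.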

Compound 4, concentration for 50% growth inhibition: 9200 nM
Compound 4: the middle estimate sits 1.2-fold (0.08 log units) above what was measured; measured number inside the range.
By their numbers in this assay, from the lowest: compounds 3, 4, 2 and 1 (each within the scatter of the next).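

Placing 6-methylpyridin-3-yl on the carbonyl carbon gives a 1.2-fold higher number from compound 3 to compound 4 (0.08 log units; within the scatter), and the comparisons with the other two pyridines give a 1.2-fold lower number from compound 2 to compound 4 (0.09 log units; within the scatter) and a 1.4-fold lower number from compound 1 to compound 4 (0.16 log units; within the scatter). So in this assay, a pyridine with methyl and no chlorine reads the same as those carrying chlorine, and all four compounds remain within the scatter of one another. At this position, chlorine is therefore not needed to keep the number in this range.

Still open, going by these compounds, is whether a pyridine carrying an amine or a carboxylic acid would move the number beyond the scatter. Nothing available here explains why these pyridines read alike.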